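This account rests on a few compounds, and the source may have more. Where it says the series, first, only, none or still open, it means among the compounds named here.

Compound 1 `O=[N+]([O-])c1ccc(C(c2c[nH]c3ccc(Br)cc23)c2c[nH]c3ccc(Br)cc23)cc1` gives 5500 nM in this study.
Compound 2 `CCCCCCCC(c1c[nH]c2ccc(Br)cc12)c1c[nH]c2ccc(Br)cc12` gives 3500 nM.
Compound 3 `N#Cc1ccc2[nH]cc(C(c3ccc([N+](=O)[O-])cc3)c3c[nH]c4ccc(C#N)cc34)c2c1` gives > 100000 nM, which is a limit of the assay and not a number.

In a functional assay on A549 cells (Homo sapiens) for inhibition, read by MTT assay, with a stated time of 48 h (a higher number here means a weaker inhibitor, a lower number a stronger inhibitor), compound 1 and compound 2 differ by one change, (heptyl in place of 4-nitrophenyl on a saturated chain carbon bound to two aromatic carbons), and that change made a step of a 1.6-fold lower number from compound 1 to compound 2 (0.20 log units; within the scatter). Compound 3 stands at the limit of > 100000 nM in this assay, at which 1 of the 3 values shown sits, so only a limit is known for it. The difference between the core of compound 1 and the core of compound 3 is not broken down here. Compound 4 `CCCCCCCC(c1c[nH]c2ccc(C#N)cc12)c1c[nH]c2ccc(C#N)cc12` has not been measured; it carries the same change relative to compound 3, (heptyl in place of 4-nitrophenyl on a saturated chain carbon bound to two aromatic carbons). Because the earlier step was a 1.6-fold lower number from compound 1 to compound 2 (0.20 log units; within the scatter), a step of a number no higher from compound 3 to compound 4 (the limit leaves the size open) is expected, resting on that single earlier pair and on compound 3 being known only as a limit, so compound 4 may itself come out as a limit. Compound 4 is estimated at 100000 nM, most likely between 30000 nM and 300000 nM.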

Compound 4, half-maximal inhibitory concentration: 26000 nM
Beside the measured number, compound 4's estimate is 3.8-fold (0.59 log units) above it, outside the stated range (below it).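

In this assay, putting heptyl in place of 4-nitrophenyl gave an at least 3.8-fold lower number from compound 3 to compound 4 (0.58 log units; beyond the scatter), so on this second core the change did not cost activity. On these data alone, the value of compound 3, > 100000 nM, is a limit of the assay and not a number, so the true size of this step remains unknown. Each core offers only one pair, which shows that the change can be carried over without loss but gives no measure of how closely its size carries over: the same change on two cores in this assay, a 1.6-fold lower number (0.20 log units; within the scatter) from compound 1 to compound 2 and an at least 3.8-fold lower number (0.58 log units; beyond the scatter) from compound 3 to compound 4; the limit leaves it open whether they differ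

The compounds shown leave open how a shorter chain, a longer chain, an amine or a carboxylic acid would behave on a saturated chain carbon bound to two aromatic carbons. They also leave open whether the same change would hold on any further core.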